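The source may hold more compounds than are shown below. What is called first, only, known or untested is meant among the compounds shown, and "the series" means these compounds.

In an ADME assay on HCT-116 cells (Homo sapiens) for cytotoxicity, read by CellTiter-Glo, with a stated time of 72 h (a higher number here means a weaker inhibitor, a lower number a stronger inhibitor), compound 3 (`CCCOc1ccc(S(=O)(=O)N2CCC(N3CCC(C)CC3)CC2)cc1`) gives > 5000 nM, which is a limit of the assay and not a number. Compound 2 (`CC1CCN(C2CCN(S(=O)(=O)c3ccccc3Br)CC2)CC1`) gives > 5000 nM, the same limit. Compound 1 (`CC1CCN(C2CCN(S(=O)(=O)c3cccnc3)CC2)CC1`) gives > 10000 nM, also a limit. None of the three therefore has a measured half-maximal inhibitory concentration.

Compound 4 (`CCc1ccc(S(=O)(=O)N2CCC(N3CCC(C)CC3)CC2)cc1`) differs from compound 3 in one place, on an aromatic carbon para to a large group, where ethyl stands in place of propoxy: ethyl in place of propoxy on an aromatic carbon. Within the data shown here, the only measured step, a step that the two limits leave unreadable from compound 1 to compound 2, concerns a different change, and its size cannot be read, so it offers no size to carry over. No step beyond the scatter is expected in this assay, and another limit is the likeliest report. The expected change is a step that the limit leaves unreadable from compound 3 to compound 4, an estimate that rests on limits alone. For compound 4 the estimated value is 8000 nM, with an expected range from 3000 nM to 20000 nM.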

Compound 4, half-maximal inhibitory concentration: > 5000 nM
Compound 4 ended at the assay's limit; the forecaster's own chance of this, stated with the estimate: 85%; the middle value is on the limit's open side.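

Compound 4 ends at a limit of the assay and not at a number, as do compound 1, compound 2 and compound 3, so none of the steps to compound 4 can be read. The compounds shown leave open whether any group on the sulfonyl sulfur changes the result in this assay.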